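A few compounds are considered here, and "the series" means these few. Any claim that something is new, unique, unknown or untested is made for them only; others in the source may bear on it.

Compound 1 `Cc1cccc(C)c1-c1cccc(COc2ccc3c(c2)OCC3CC(=O)O)c1` is measured in a functional assay on CHO cells for agonist activity at Free fatty acid receptor 1 (Homo sapiens), read by FLIPR, with a stated time of 90 s, in the presence of a further agent that is not named here (a higher number here means that more compound is needed for the effect, a lower number that less compound is needed), where compound 1 gives 27 nM. Compound 2 `COc1ccc(COc2ccc3c(c2)OCC3CC(=O)O)cc1-c1c(C)cccc1C` gives 24 nM. Compound 1 stands at the higher of the two numbers, with compound 2 nearest, but the step of a 1.1-fold lower number from compound 1 to compound 2 (0.05 log units; within the scatter) means the two cannot be told apart.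

Compound 3 `Cc1ccc(-c2cccc(COc3ccc4c(c3)OCC4CC(=O)O)c2)c(C)c1` differs from compound 1 in another way: 2,4-dimethylphenyl in place of 2,6-dimethylphenyl on an aromatic carbon. Among the measured compounds shown here, the only measured step, from compound 1 to compound 2, changes a different place, a methoxy for a hydrogen, and stays within the scatter, so it says nothing direct about swapping one dimethylphenyl for another. For the measured compounds named here, with no step bearing on this change, the expectation can only be a modest shift and a wide range.

Compound 3 is therefore estimated at 70 nM, between 20 nM and 250 nM, an expected step of a 2.6-fold higher number from compound 1 to compound 3 (0.41 log units; beyond the scatter).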

Compound 3, half-maximal effective concentration: 29 nM
For compound 3 the middle estimate is 2.4-fold (0.38 log units) above the measured one; low and high end bracket the measured number.
By their numbers in this assay, from the lowest: compounds 2, 1 and 3 (each within the scatter of the next).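

Exchanging 2,6-dimethylphenyl for 2,4-dimethylphenyl keeps the same atoms but joins them differently, and in this assay this gives a 1.1-fold higher number from compound 1 to compound 3 (0.03 log units; within the scatter). The earlier compounds shown here tested only a methoxy in place of a hydrogen, whereas this pair shows that, on this aromatic carbon, the 2,6-dimethylphenyl and 2,4-dimethylphenyl groups cannot be told apart by this read-out. No measurement shown here offers an explanation for this match.

The compounds shown leave open whether other arrangements of the two methyl groups, such as 3,5-dimethylphenyl, would give a similar number, and how an unsubstituted phenyl, an amine or a carboxylic acid would behave at this place. From the compounds shown here alone, it also remains open whether the methoxy of compound 2 and the 2,4-dimethylphenyl of compound 3 would give a similar number when combined in one molecule.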